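Shifting a methyl on the outer ring of compound 2

The compounds below may be only part of what the source reports. "The series", "measured", "known", "first", "only" and "open" are said of these compounds alone.

Of the compounds shown here, three that share one core have been tested in a functional assay on CHO cells for agonist activity at Alpha-2C adrenergic receptor (Homo sapiens); a lower number here means a smaller maximal response, a higher number a larger maximal response. Compound 1, `CC(Oc1ccccc1-c1ccc([N+](=O)[O-])cc1)C1=NCCN1`, reaches only a limit of the assay, < 0.3. Compound 3, `CC(Oc1ccccc1-c1ccccc1[N+](=O)[O-])C1=NCCN1`, likewise reaches only a limit, < 0.3. For the measured compounds named here, compound 2, `Cc1ccc(-c2ccccc2OC(C)C2=NCCN2)cc1`, gives 0.46, and among the three it is the only one with a number rather than a limit. Going by the values given here, the single measured step, a number at least 0.16 higher from compound 1 to compound 2 (beyond the scatter), lifts the response out of the limit of < 0.3 in this assay, at which 2 of the 3 values shown sit, so the methyl group carries the measurable activity seen so far.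

Compound 4, `Cc1cccc(-c2ccccc2OC(C)C2=NCCN2)c1`, has not yet been measured. It differs from compound 2 by 3-methylphenyl in place of 4-methylphenyl on an aromatic carbon. Among the compounds with values here, no measured step changes the position of a methyl group, so nothing here speaks directly to this change; the one measured step swaps a nitro for a methyl, which is a different kind of move. The expectation is therefore a response close to that of compound 2, with a step of a number 0.020 lower from compound 2 to compound 4 (within the scatter) that may well stay within the scatter. Compound 4 is estimated to give 0.44, in the range 0.3 to 0.6.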

Compound 4, intrinsic activity: the largest response reached, as a fraction of the reference agonist's: 0.6
Compound 4: middle estimate off by 0.16, on the low side; low and high end bracket the measured number.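

The place of the methyl on the outer ring matters in this assay: the change to 3-methylphenyl in place of 4-methylphenyl gives a number 0.14 higher from compound 2 to compound 4 (beyond the scatter). The earlier compounds shown here showed only a step in which a methyl replaced a nitro, so they said nothing about where on that ring a group sits. Here the two compounds have the same atoms, joined differently, so rearranging those atoms alone is enough to shift the maximal response by more than the usual scatter.

As far as these compounds go, the nitro compounds offer no matching comparison of place, as neither gives a number to set against the other: the limit of < 0.3 in this assay, at which 2 of the 4 values shown sit. Also open is whether a group other than methyl, such as an amine or a longer ethyl chain, would show the same preference for that place on the outer ring.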